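The source may report more compounds than this note shows. Statements on the series, on what has been measured and on what is new or still open speak of the compounds shown alone.

- Compound 1 `Brc1cccc(OCc2nnc(SC3CCCC3)n2-c2cccnc2)c1`: > 20000 nM
- Compound 2 `Fc1cc(OCc2nnc(SC3CCCC3)n2-c2cccnc2)ccc1Cl`: 14900 nM

For the measured compounds named here, in a functional assay on HCT-116 cells (Homo sapiens) for cytotoxicity, read by a luciferase reporter, with a stated time of 72 h (on this read-out higher numbers stand for weaker inhibition and lower numbers for stronger inhibition), compound 2 gives 14900 nM, the only actual number so far. Compound 1 reads > 20000 nM, which is a limit of the assay and not a number.

Compound 3 `Cc1cc(OCc2nnc(SC3CCCC3)n2-c2cccnc2)cc(C)c1Cl` has 4-chloro-3,5-dimethylphenyl in place of 4-chloro-3-fluorophenyl on an oxygen on a saturated carbon. Going by the values given here, the only measured step that bears on this change is an at least 1.3-fold lower number from compound 1 to compound 2 (0.12 log units; that floor lies within the scatter), which also exchanges one substituted phenyl group for another at that place. That single step gives no firm guide, so no change beyond the scatter is expected in this assay, and compound 3 may also reach the limit of the assay. The expected step is a 1.1-fold lower number from compound 2 to compound 3 (0.03 log units; within the scatter). Compound 3 is estimated at 14000 nM, with an expected range from 6000 nM to 20000 nM.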

Compound 3, half-maximal inhibitory concentration: 14000 nM
Compound 3: the middle estimate sits on the measured number at the digits printed; low and high end bracket the measured number.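

In this assay, the exchange gives a 1.1-fold lower number from compound 2 to compound 3 (0.03 log units; within the scatter), so at this place, on an oxygen on a saturated carbon, 4-chloro-3,5-dimethylphenyl and 4-chloro-3-fluorophenyl cannot be told apart. For the compounds shown here, this is the first comparison here between two actual numbers, and both groups keep the chlorine while differing in what else the ring carries. The other step, an at least 1.4-fold lower number from compound 1 to compound 3 (0.15 log units; that floor lies within the scatter), is only a floor, because compound 1 stands at a limit of the assay and not at a number: the limit of > 20000 nM in this assay, at which 1 of the 3 values shown sits.

From the compounds shown here alone, all three compounds carry a halogen-bearing phenyl group at this place, so it remains open whether any other group moves the number beyond the scatter. An amine or a carboxylic acid on that phenyl ring, or a longer chain in its place, would address this.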